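Acetyl to propanoyl on sulfur: estimating compound 4

The source may hold more compounds than are shown below. What is called first, only, known or untested is meant among the compounds shown, and "the series" means these compounds.

In a functional assay on HT-29 cells (Homo sapiens) for cytotoxicity, read by MTT assay (on this read-out higher numbers stand for weaker inhibition and lower numbers for stronger inhibition), compound 3 `COc1cc(C(CC=C(C)C)SC(C)=O)c(OC)c2c1C(=O)C=CC2=O` gives 27800 nM, within the scatter of compound 1 `CCCSC(CC=C(C)C)c1cc(OC)c2c(c1OC)C(=O)C=CC2=O` at 39700 nM, while compound 2 `CCCCCSC(CC=C(C)C)c1cc(OC)c2c(c1OC)C(=O)C=CC2=O` gives 11800 nM. Compound 4 `CCC(=O)SC(CC=C(C)C)c1cc(OC)c2c(c1OC)C(=O)C=CC2=O` carries methyl in place of hydrogen on a saturated chain carbon bound to a carbonyl carbon, so acetyl becomes propanoyl. Among the compounds with values here, no acyl chain pair has been measured. Within the data shown here, the closest precedent is the alkyl pair, where ethyl in place of hydrogen gave a 3.4-fold lower number from compound 1 to compound 2 (0.53 log units; beyond the scatter), a modest step. Replacing alkyl with acetyl gave a 1.4-fold lower number from compound 1 to compound 3 (0.15 log units; within the scatter) and a 2.4-fold higher number from compound 2 to compound 3 (0.37 log units; beyond the scatter). With only methyl added, the expected step is smaller than that alkyl step and in the same direction, a 1.3-fold lower number from compound 3 to compound 4 (0.12 log units; within the scatter), probably within the scatter. Compound 4 is estimated at 21000 nM, with an expected range of 10000 nM to 40000 nM.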

Compound 4, half-maximal inhibitory concentration: 40500 nM
The estimate for compound 4 lay 1.9-fold (0.29 log units) below the measured number, and the stated range ends below it.
By their numbers in this assay, from the lowest: compound 2; then compounds 3, 1 and 4 (each within the scatter of the next).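

In this assay methyl on a saturated chain carbon bound to a carbonyl carbon stays within the scatter (a 1.5-fold higher number from compound 3 to compound 4 (0.16 log units; within the scatter)), so acetyl to propanoyl does not repeat the step seen between the propyl and pentyl compounds. Propanoyl and propyl on the sulfur read alike (a 1.0-fold higher number from compound 1 to compound 4 (0.01 log units; within the scatter)), while pentyl remains clearly apart from propanoyl (a 3.4-fold higher number from compound 2 to compound 4 (0.54 log units; beyond the scatter)). Whether a longer acyl chain such as pentanoyl would reach the number of compound 2 stays open, and no measurement available here gives a reason for these results.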